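A Dichlorophenyl Swap on an Inactive Sulfonyl Hydrazide

The compounds below may be only part of what the source reports. "The series", "measured", "known", "first", "only" and "open" are said of these compounds alone.

Compound 1 `CC(=O)Nc1ccc(S(=O)(=O)NNC(=O)c2cccnc2Nc2ccc(Cl)cc2)cc1` is a sulfonyl hydrazide whose sulfonyl sulfur carries a 4-acetamidophenyl group. In a functional assay on BT-549 cells (Homo sapiens) for antiproliferative activity (on this read-out lower numbers stand for higher toxicity in this test and higher numbers for lower toxicity in this test), compound 1 gives > 100000 nM, which is a limit of the assay rather than a measured number. Compound 2 `O=C(NNS(=O)(=O)c1ccc(F)cc1)c1cccnc1Nc1ccc(Cl)cc1Cl` shares the core of compound 1 but carries different aryl groups at both ends. In this assay compound 2 gives > 100000 nM, again a limit. Compound 1 thus stands at the limit, and because the limit of > 100000 nM in this assay, at which 2 of the 2 values shown sit, there is no real number to compare against. Compound 3 `O=C(NNS(=O)(=O)c1ccc(Cl)cc1Cl)c1cccnc1Nc1ccc(Cl)cc1` has not been tested yet; it differs from compound 1 by 2,4-dichlorophenyl in place of 4-acetamidophenyl on a sulfonyl sulfur. Among the compounds with values here, with no measured step to draw on, the expected step is a number no higher from compound 1 to compound 3 (the limit leaves the size open), none beyond the usual scatter. Compound 3 is therefore estimated at 100000 nM, between 30000 nM and 300000 nM, most likely reported again only as a limit.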

Compound 3, concentration lethal to 50% of the cells: 72400 nM
Compound 3: middle estimate off by 1.4-fold (0.14 log units), on the high side; measured number inside the range.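

Compound 3 is the only compound shown here that gives a real number rather than a limit, so this position on the sulfonyl sulfur can carry a group that yields a readable value in this assay. Replacing 4-acetamidophenyl with 2,4-dichlorophenyl gives an at least 1.3-fold lower number from compound 1 to compound 3 (0.14 log units; that floor lies within the scatter), which means that no change beyond the usual scatter can be claimed. The full size of the step stays unknown because one end of it is not a number: the limit of > 100000 nM in this assay, at which 2 of the 3 values shown sit.

From the compounds shown here alone, whether both chlorine atoms matter stays open, as does what a plain phenyl group or a phenyl group bearing an amine would give on the same sulfonyl sulfur. Compound 2 differs from compound 3 in more than one place, so that pair cannot show which change matters.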